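The source may hold more compounds than are shown below. What is called first, only, known or untested is meant among the compounds shown, and "the series" means these compounds.

Measured in an ADME assay on Vero cells (Chlorocebus sabaeus) for cytotoxicity, read by neutral red uptake, tested at 394 ug/mL; a higher number here means a weaker effect of the compound at the concentration tested, a lower number a stronger effect: compound 1 `O=C1CSC(c2ccc(O)cc2)N1CCN1CCCCC1` gives 76%; compound 2 `Cc1ccc(C2SCC(=O)N2CCN2CCCCC2)cc1` gives 51%.

Compound 2 stands lowest of the two numbers, its nearest neighbour being compound 1, which lies higher by a step beyond the scatter. For the measured compounds named here, compound 3 `O=C1CSC(c2cccc(F)c2)N1CCN1CCCCC1` differs from compound 2 in one place: 3-fluorophenyl in place of 4-methylphenyl on a saturated ring carbon The only measured step, a number 25 percentage points lower from compound 1 to compound 2 (beyond the scatter), bears on this change loosely, since it swaps substituents without exchanging one ring group for another. The expected step is therefore small and of uncertain direction: a number 7 percentage points higher from compound 2 to compound 3 (within the scatter). Compound 3 is estimated at 58% in this assay, ranging from 40% to 78%.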

Compound 3, a percentage reported as activity, at one concentration (the size of the read-out at that concentration, not a potency): 60%
The estimate for compound 3 lay 2 percentage points below the measured number; low and high end bracket the measured number.
By their numbers in this assay, from the lowest: compounds 2 and 3 (each within the scatter of the next); then compound 1.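

At the saturated ring carbon, 3-fluorophenyl in place of 4-methylphenyl gives a number 9 percentage points higher from compound 2 to compound 3 (within the scatter) and so does not separate these two groups in this assay. 3-fluorophenyl in place of 4-hydroxyphenyl gives a number 16 percentage points lower from compound 1 to compound 3 (beyond the scatter) and so shows that a second replacement of 4-hydroxyphenyl also lies beyond the scatter. No evidence is available that explains either step. The compounds shown leave open how an amine or a carboxylic acid on the aromatic ring would read here. They also leave open whether a longer chain between the aromatic ring and the shared core would change the number.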